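A few compounds are considered here, and "the series" means these few. Any claim that something is new, unique, unknown or untested is made for them only; others in the source may bear on it.

In a functional assay on DU-145 cells (Homo sapiens) for inhibition, read by trypan blue exclusion, with a stated time of 96 h (a lower number here means a stronger inhibitor of growth, a higher number a weaker inhibitor of growth), compound 1 (`Cc1ccc(CS/C(=C/c2c[nH]c3ccc(Br)cc23)C(=O)c2ccc(Cl)cc2)cc1`) gives 1000 nM, while compound 2 (`Cc1ccc(CS/C(=C/c2sccc2C)C(=O)c2ccc(Cl)cc2)cc1`) gives 10000 nM, the higher of the two numbers. Compound 3 (`Cc1ccc(CS/C(=C/c2cc([N+](=O)[O-])ccc2F)C(=O)c2ccc(Cl)cc2)cc1`) has 2-fluoro-5-nitrophenyl in place of 3-methylthiophen-2-yl on a double-bonded chain carbon bound to a double-bonded chain carbon. Among the compounds with values here, only one measured step bears on this place, a 10-fold higher number from compound 1 to compound 2 (1.00 log units; beyond the scatter), so the group on this carbon can move the number by a modest amount. Within the data shown here, no measured compound carries the entering group. A modest move to a lower number is expected in this assay, and the estimated step is a 2.5-fold lower number from compound 2 to compound 3 (0.40 log units; beyond the scatter). For compound 3 the estimate is 4000 nM, with an expected range of 800 nM to 20000 nM.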

Compound 3, concentration for 50% growth inhibition: 1000 nM
Compound 3: the middle estimate sits 4.0-fold (0.60 log units) above what was measured, and the stated range covers the measured number.
By their numbers in this assay, from the lowest: compounds 1 and 3 (each within the scatter of the next); then compound 2.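

In this assay, 2-fluoro-5-nitrophenyl on this carbon gives a 10-fold lower number from compound 2 to compound 3 (1.00 log units; beyond the scatter) and so matches what 5-bromo-1H-indol-3-yl achieved over 3-methylthiophen-2-yl. The comparison with the indole shows no change at the digits printed from compound 1 to compound 3 (within the scatter) and means that, among these compounds, the lower number does not depend on 5-bromo-1H-indol-3-yl: a six-membered aromatic ring of carbon only also reaches it. No measurement on hand explains this equivalence. On these data alone, it remains open whether the fluoro or the nitro group carries the step, and how a phenyl ring bearing an amine or a carboxylic acid would behave on this carbon.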